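Changing One Ester Group on Compound 1

The source may report more compounds than this note shows. Statements on the series, on what has been measured and on what is new or still open speak of the compounds shown alone.

Measured compounds:
compound 1, `Cc1c(C(=O)OC(C)C(C)(C)C)c[nH]c1C(=O)Oc1cccnc1`: 720 nM
compound 2, `CCCOC(=O)c1[nH]c(C=O)c(C(=O)OC(C)(C)C)c1C`: 2000 nM
compound 3, `C=CCOC(=O)Cn1c(C)c(C(=O)OC(C)(C)C)c(C)c1C(=O)OCCC`: 12600 nM

All three were tested in an assay on CHO cells for inhibition of metabotropic glutamate receptor 1 (Rattus norvegicus); on this read-out higher numbers stand for weaker inhibition and lower numbers for stronger inhibition. Compound 1 has the lowest number of the three, and its gaps to both compound 2 and compound 3 lie beyond the usual scatter, so on this read-out compound 1 is the strongest inhibitor shown. Compound 2 is the nearer of the two, compound 3 the furthest.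

The step under consideration goes from compound 1 to compound 4, `Cc1c(C(=O)OC(C)C(C)(C)C)c[nH]c1C(=O)OC(C)CN(C)C`, which has not yet been measured. The change is 1-((dimethylamino)methyl)ethyl in place of pyridin-3-yl on an oxygen next to a carbonyl group. The ester group itself stays; only the group on the oxygen next to the carbonyl is exchanged, a ring for an open chain of the same atom count.

For the measured compounds named here, no measured pair shows this kind of exchange, so there is no direct guide. The expectation is that compound 4 gives a somewhat higher number than compound 1 in this assay, a step of a 3.5-fold higher number from compound 1 to compound 4 (0.54 log units; beyond the scatter), with a wide margin in either direction. The estimate for compound 4 in this assay is 2500 nM, within a range from 600 nM to 10000 nM.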

Compound 4, half-maximal inhibitory concentration: 390 nM
Compound 4: the middle estimate sits 6.4-fold (0.81 log units) above what was measured, and the stated range ends above it.
By their numbers in this assay, from the lowest: compounds 4 and 1 (each within the scatter of the next); then compound 2; then compound 3.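

In this assay, putting the open 1-((dimethylamino)methyl)ethyl chain in place of the pyridin-3-yl ring on an oxygen next to a carbonyl group gives a 1.8-fold lower number from compound 1 to compound 4 (0.27 log units; within the scatter), so on this read-out the two compounds cannot be told apart. For the compounds shown here, this is the first direct look at this place, since compounds 2 and 3 differ from compound 1 in more than one place and offered no such comparison. It shows that, for this pair of groups, the aromatic ring is not needed to keep the number in the range of compound 1, and that an open chain with the same count of heavy atoms serves equally well on this read-out, though nothing available explains why the two groups read alike.

Still open, as far as these compounds go, is whether the nitrogen of the chain matters at all, which a plain carbon chain such as isopropyl in the same place would test. Equally open, from the compounds shown here alone, is how far this tolerance extends, for instance to a longer chain carrying the dimethylamino group, to a carboxylic acid at the end of the chain, or to a pyridin-4-yl ring.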